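The source may hold more compounds than are shown below. What is called first, only, known or untested is meant among the compounds shown, and "the series" means these compounds.

Compound 1 `CCn1c(C(=O)NCC#N)ccc1C(CC)(CC)c1ccc(OCCC(O)(CC)CC)c(C)c1`: 17800 nM
Compound 2 `CCC(C)C(NC(=O)c1ccc(C(CC)(CC)c2ccc(OCCC(O)(CC)CC)c(C)c2)n1CC)C(=O)OC`: > 50000 nM

These values come from a functional assay on PC-3 cells (Homo sapiens) for antiproliferative activity, read by MTT assay, with a stated time of 48 h; a lower number here means a stronger inhibitor, a higher number a weaker inhibitor. In this assay, compound 2 gives > 50000 nM, which is a limit of the assay and not a number.

Compound 3 `CCC(C)C(NC(=O)c1ccc(C(CC)(CC)c2ccc(OCCC(O)(CC)CC)c(C)c2)n1CC)C(=O)O` differs from compound 2 in one place: hydrogen in place of methyl on an oxygen next to a carbonyl group. In words, hydrogen takes the place of methyl on an oxygen next to a carbonyl group, turning methoxycarbonyl into carboxy.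

Among the measured compounds shown here, the one measured step, an at least 2.8-fold higher number from compound 1 to compound 2 (0.44 log units; beyond the scatter), lies on an amide-type nitrogen, so it does not measure this change directly. It does show that compound 2 ended up weaker than compound 1, and nothing measured points to a recovery. From the compounds shown here alone, no step beyond the scatter is therefore expected, and the direction stays open. The estimated step is a number no higher from compound 2 to compound 3 (the limit leaves the size open).

Compound 3 is expected at 50000 nM, with an estimated range of 20000 nM to 120000 nM.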

Compound 3, half-maximal inhibitory concentration: 13800 nM
Beside the measured number, compound 3's estimate is 3.6-fold (0.56 log units) above it, outside the stated range (below it).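

Replacing methyl with hydrogen on an oxygen next to a carbonyl group, which turns methoxycarbonyl into carboxy, gives an at least 3.6-fold lower number from compound 2 to compound 3 (0.55 log units; beyond the scatter) in this assay, so this single small change moves the number beyond the scatter. Compound 2 stands at a limit of the assay and not a number, so the full size of that step stays open: the limit of > 50000 nM in this assay, at which 1 of the 3 values shown sits.

With carboxy in place, 1-carboxy-2-methylbutyl instead of cyanomethyl on the amide-type nitrogen gives a 1.3-fold lower number from compound 1 to compound 3 (0.11 log units; within the scatter), which lies within the scatter, so the larger chain does not by itself go with a weaker number.

From the compounds shown here alone, it remains open whether a primary amide or a hydroxymethyl group in place of the carboxy would give a similar number. A shorter chain carrying carboxy, such as carboxymethyl, also remains an open comparison with cyanomethyl.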